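A few compounds are considered here, and "the series" means these few. Any claim that something is new, unique, unknown or untested is made for them only; others in the source may bear on it.

Of the compounds shown here, two share one core and have been tested in an ADME assay on MT2 cells (Homo sapiens) for cytotoxicity; a lower number here means that less compound is tolerated, a higher number that more compound is tolerated. Compound 1 `CC1(C)OC(=O)C2(C(=O)O1)[C@@H](c1ccco1)CC(=O)C[C@H]2c1c[nH]c2ccccc12` carries a 1H-indol-3-yl group on a saturated ring carbon. In this assay compound 1 gives > 111000 nM, which is a limit of the assay and not a number. Compound 2 `CC1(C)OC(=O)C2(C(=O)O1)[C@@H](c1ccco1)CC(=O)C[C@H]2c1ccccc1Cl` carries 2-chlorophenyl in place of 1H-indol-3-yl on a saturated ring carbon. In this assay compound 2 gives > 111000 nM, again a limit rather than a number. The step that the two limits leave unreadable from compound 1 to compound 2 therefore cannot be read, since both values sit at the limit of > 111000 nM in this assay, at which 2 of the 2 values shown sit. Among the compounds with values here, compound 2 thus stands at a limit, and so does the only other value shown.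

Compound 3 `COc1cc([C@@H]2CC(=O)C[C@H](c3ccco3)C23C(=O)OC(C)(C)OC3=O)ccc1O` is not yet measured. It differs from compound 2 in one place: 4-hydroxy-3-methoxyphenyl in place of 2-chlorophenyl on a saturated ring carbon. Within the data shown here, the one measured step changes the same saturated ring carbon, but its size is not readable, so no direction can be drawn from it. The expectation is a step that the limit leaves unreadable from compound 2 to compound 3 that stays within the scatter. Compound 3 is expected to give about 150000 nM, between 60000 nM and 400000 nM, most likely once more as a limit.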

Compound 3, half-maximal cytotoxic concentration: > 111000 nM
Compound 3 gave a limit, no number (the forecaster's own chance of this, stated with the estimate: 80%); the middle value does not contradict the limit.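

The steps from compound 1 and compound 2 to compound 3 cannot be read in this assay because all three compounds stop at the same limit, which is not a number: the limit of > 111000 nM in this assay, at which 3 of the 3 values shown sit.

The compounds shown leave open whether the 1H-indol-3-yl, 2-chlorophenyl and 4-hydroxy-3-methoxyphenyl groups differ at all in cytotoxicity.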